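Topoisomerase 1 inhibitors: fused diamine in place of pyrrolidine

A few compounds are considered here, and "the series" means these few. Any claim that something is new, unique, unknown or untested is made for them only; others in the source may bear on it.

Measured so far in an assay on isolated protein for inhibition of DNA topoisomerase 1 (Homo sapiens), with a stated time of 15 min; on this read-out higher numbers stand for weaker inhibition and lower numbers for stronger inhibition:
compound 1 `CNCCCNc1c(F)cc2c(=O)c(C(=O)O)cn(Cc3ccc(-c4ccccc4)cc3)c2c1OC`, 101000 nM
compound 2 `CN[C@@H]1CCN(c2cc3c(cc2F)c(=O)c(C(=O)O)cn3Cc2ccc(-c3ccccc3)cc2)C1`, 34800 nM
compound 3 `CNC[C@@H]1CCN(c2c(F)cc3c(=O)c(C(=O)O)cn(Cc4ccc(-c5ccccc5)cc4)c3c2OC)C1`, 155000 nM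

Compound 2 stands lowest of the three numbers, with compound 1 nearest and compound 3 furthest, both gaps beyond the scatter. Compound 4 `O=C(O)c1cn(Cc2ccc(-c3ccccc3)cc2)c2cc(N3CC4CNCC4C3)c(F)cc2c1=O` differs from compound 2 in one place: a group of 8 heavy atoms (6 carbon, 2 nitrogen; 2 five-membered non-aromatic rings with 1 hetero atom each) in place of a group of 7 heavy atoms (5 carbon, 2 nitrogen; one five-membered non-aromatic ring with 1 hetero atom), on an aromatic carbon.

For the measured compounds named here, the only measured step at this aromatic carbon is a 1.5-fold higher number from compound 1 to compound 3 (0.19 log units; within the scatter), which trades an open chain for a single ring and stays within the scatter. Going by the values given here, no measured step trades one ring for two fused rings, so the present change has no direct precedent; with the one related step flat, no movement beyond the scatter is expected, although the direction remains open.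

Compound 4 is therefore estimated at 40000 nM, in a range of 12000 nM to 130000 nM, an expected step of a 1.1-fold higher number from compound 2 to compound 4 (0.06 log units; within the scatter).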

Compound 4, half-maximal inhibitory concentration: 33300 nM
Estimate against measurement, compound 4: 1.2-fold (0.08 log units) above; measured number inside the range.
By their numbers in this assay, from the lowest: compounds 4 and 2 (each within the scatter of the next); then compounds 1 and 3 (each within the scatter of the next).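

At this aromatic carbon, ortho to a fluoro group, the two-ring group takes the place of 3-(methylamino)pyrrolidin-1-yl and its defined stereocentre with a 1.0-fold lower number from compound 2 to compound 4 (0.02 log units; within the scatter) in this assay. For the compounds shown here, this is the first step here from one ring to two fused rings, and it leaves the two compounds indistinguishable on this read-out. Nothing available explains this flat result. On these data alone, whether a piperazin-1-yl group or a primary amine at this carbon would move the number beyond the scatter stays open.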